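Hydroxypiperidine amide in a spirocyclic cholesterol-transporter series

This account rests on a few compounds, and the source may have more. Where it says the series, first, only, none or still open, it means among the compounds named here.

Compound 1 `CC(C)(C)OC(=O)NCCNC(=O)CN1CN(c2ccccc2)C2(CCN(C(=O)c3ccc(C4CCCCC4)cc3)CC2)C1=O` — 5500 nM
Compound 2 `CC(C)(C)c1ccc(C(=O)N2CCC3(CC2)C(=O)N(CC(=O)NCN)CN3c2ccccc2)cc1` — 26500 nM
Compound 3 `CC(C)(C)OC(=O)NCCCCCNC(=O)CN1CN(c2ccccc2)C2(CCN(C(=O)c3ccc(C(C)(C)C)cc3)CC2)C1=O` — 13700 nM

Of the compounds shown here, three sharing a spirocyclic core have been tested in an assay on HEK293 cells for displacement of a labelled ligand from NPC1-like intracellular cholesterol transporter 1 (Homo sapiens); on this read-out higher numbers stand for weaker inhibition and lower numbers for stronger inhibition. Compound 2 stands at the highest number of the three. Its nearest neighbour is compound 3, reached by the step of a 1.9-fold lower number from compound 2 to compound 3 (0.29 log units; within the scatter), a change on the same amide-bearing side chain that is within the scatter. Among the measured compounds shown here, compound 1, which differs from compound 2 in more than one place, sits at a lower number than compound 2, so only the two values can be compared and no single step is attributed to the gap.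

Compound 4 `CC(C)(C)c1ccc(C(=O)N2CCC3(CC2)C(=O)N(CC(=O)N2CCCC(O)C2)CN3c2ccccc2)cc1` remains to be measured. It is obtained from compound 2 by the change 3-hydroxypiperidin-1-yl in place of (aminomethyl)amino on a carbonyl carbon

For the measured compounds named here, the only step that bears on this change is the one from compound 2 to compound 3, which also altered the group on this carbonyl side chain and stayed within the scatter. Going by the values given here, no step in this set speaks for a sizeable movement on replacing the chain amide with a ring amide. The expectation for compound 4 in this assay is therefore a step of about a 1.3-fold lower number from compound 2 to compound 4 (0.12 log units; within the scatter), that is, no change beyond the scatter. Compound 4 is estimated at 20000 nM, with a range from 6000 nM to 60000 nM.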

Compound 4, half-maximal inhibitory concentration: 12200 nM
For compound 4 the middle estimate is 1.6-fold (0.21 log units) above the measured one, and the stated range covers the measured number.
By their numbers in this assay, from the lowest: compound 1; then compounds 4, 3 and 2 (each within the scatter of the next, the first and the last beyond it).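

In this assay, putting 3-hydroxypiperidin-1-yl in place of (aminomethyl)amino on the carbonyl carbon gives a 2.2-fold lower number from compound 2 to compound 4 (0.34 log units; beyond the scatter), a modest move but the first at this position to lie beyond the scatter, whereas a 1.9-fold lower number from compound 2 to compound 3 (0.29 log units; within the scatter) stayed within it. The position therefore accepts a six-membered non-aromatic ring, with 7 heavy atoms entering where 3 leave, and the number falls rather than rises. Compound 3 at 13700 nM and compound 4 at 12200 nM lie within the scatter of each other, so an open chain ending in a tert-butoxycarbonyl-protected amine and a ring attached through its nitrogen cannot be told apart on this read-out.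

Nothing in the material shows whether the step goes with the ring, with the hydroxyl or with the loss of (aminomethyl)amino. Still open, on these data alone, is how a plain piperidin-1-yl, a morpholin-4-yl or a 4-hydroxypiperidin-1-yl on this carbonyl carbon would compare with 3-hydroxypiperidin-1-yl in this assay, and whether the step would carry over to compounds bearing the cyclohexyl group of compound 1.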